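The source may hold more compounds than are shown below. What is called first, only, known or untested is meant among the compounds shown, and "the series" means these compounds.

Working notes on the series.

For the measured compounds named here, compound 3 `COc1ccc(F)c([C@H]2CC[C@H](COc3cccc([C@H](C4CC4)[C@@H](F)C(=O)O)c3)CC2)c1` gives the lowest of the three numbers measured so far in a functional assay on HEK293 cells for agonist activity at Free fatty acid receptor 1 (Homo sapiens), read by FLIPR and calcium flux; a lower number here means that less compound is needed, a higher number that more compound is needed for the effect: compound 3 gives 1.1 nM. Compound 1 `COc1ccc(F)c([C@H]2CC[C@H](COc3cccc([C@H](C4CC4)[C@@H](C)C(=O)O)c3)CC2)c1` stands nearest, and in this assay compound 1 gives 2.2 nM; the step of a 2.0-fold lower number from compound 1 to compound 3 (0.30 log units; within the scatter) lies within the scatter, so no order between compound 1 and compound 3 is claimed. Compound 2 `COc1ccc(F)c([C@H]2CC[C@H](COc3cccc([C@H](C4CC4)[C@H](F)C(=O)O)c3)CC2)c1` is furthest away: in this assay compound 2 gives 54 nM, and the step of a 49-fold lower number from compound 2 to compound 3 (1.69 log units; beyond the scatter) is large because of the fact that compounds 2 and 3 differ only in the configuration as drawn.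

Compound 4 `COc1ccc(F)c([C@H]2CC[C@H](COc3cccc([C@H](C4CC4)C(C)(C)C(=O)O)c3)CC2)c1` carries the change (1-carboxy-1-methylethyl in place of carboxy(fluoro)methyl on a saturated chain carbon bound to an aromatic carbon and a saturated ring carbon). The measured steps that bear on it are a 25-fold higher number from compound 1 to compound 2 (1.39 log units; beyond the scatter) and a 2.0-fold lower number from compound 1 to compound 3 (0.30 log units; within the scatter): the carbon bound to the carbonyl tolerates methyl in one configuration and fluoro in one configuration about equally, yet the other fluoro configuration costs much. Compound 4 removes that stereocentre and places two methyl groups there. Going by the values given here, no measured pair tells what a second methyl does, so a moderate loss is assumed rather than read off; the step of a 14-fold higher number from compound 3 to compound 4 (1.13 log units; beyond the scatter) is the expected size and direction.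

For compound 4 the estimate in this assay is 15 nM, with a range from 3 nM to 80 nM.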

Compound 4, half-maximal effective concentration: 0.11 nM
The estimate for compound 4 lay 140-fold (2.13 log units) above the measured number; measured number outside the range, below it.
By their numbers in this assay, from the lowest: compound 4; then compounds 3 and 1 (each within the scatter of the next); then compound 2.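

In this assay, the second methyl on the saturated chain carbon bound to a carbonyl carbon brings a gain rather than a loss: the record shows a 20-fold lower number from compound 1 to compound 4 (1.30 log units; beyond the scatter), and against the fluoro analogue with the better configuration it shows a 10-fold lower number from compound 3 to compound 4 (1.00 log units; beyond the scatter). Until now, methyl and fluoro at this carbon could not be ordered, so the position looked merely tolerant, whereas 1-carboxy-1-methylethyl separates from both 1-carboxyethyl and carboxy(fluoro)methyl, and a defined stereocentre at this carbon proves unnecessary for the lowest number in the series, with the widest gap being a 490-fold lower number from compound 2 to compound 4 (2.69 log units; beyond the scatter). Nothing shown explains why the added methyl lowers the number.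

On these data alone, it remains open whether the gain belongs to the two methyl groups themselves or to any double substitution at this carbon. Two fluoro groups, an ethyl in place of one methyl, or a cyclopropyl ring built on this carbon would help separate these readings, and the version with only hydrogens there would give the baseline for all of these steps.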